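Changing the aromatic group on the amide of compound 1

A few compounds are considered here, and "the series" means these few. Any claim that something is new, unique, unknown or untested is made for them only; others in the source may bear on it.

Compound 1 `CN(C)CCNc1cc2c(cn1)cc(NC(=O)c1cc3ccccc3s1)c(=O)n2C` gives 3570 nM
Compound 2 `CC(=O)Nc1cc2cnc(NCCN(C)C)cc2n(C)c1=O` gives > 100000 nM (a limit)

Among the compounds with values here, in a functional assay on MDA-MB-468 cells (Homo sapiens) for antiproliferative activity, read by MTT assay, with a stated time of 48 h (on this read-out higher numbers stand for weaker inhibition and lower numbers for stronger inhibition), compound 1 holds the only exact number so far, 3570 nM on this scale. Compound 2 stands at > 100000 nM as a limit and not a number.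

Compound 3 `COc1ccc(C(=O)Nc2cc3cnc(NCCN(C)C)cc3n(C)c2=O)cc1` keeps the core of compound 1 and differs by 4-methoxyphenyl in place of 1-benzothiophen-2-yl on a carbonyl carbon in one place: 4-methoxyphenyl in place of 1-benzothiophen-2-yl on a carbonyl carbon.

Within the data shown here, only one measured step bears on this place: an at least 28-fold higher number from compound 1 to compound 2 (1.44 log units; beyond the scatter) with methyl as the new group. Unlike methyl, 4-methoxyphenyl keeps an aromatic ring, so a far smaller step than an at least 28-fold higher number from compound 1 to compound 2 (1.44 log units; beyond the scatter) is expected in this assay and most likely toward a somewhat higher number. The expected change is a 2.2-fold higher number from compound 1 to compound 3 (0.35 log units; beyond the scatter) in size. For compound 3 the estimate is 8000 nM with an expected range of 2500 nM to 30000 nM on this scale.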

Compound 3, half-maximal inhibitory concentration: 15700 nM
The estimate for compound 3 lay 2.0-fold (0.29 log units) below the measured number, and the stated range covers the measured number.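

In this assay, the aromatic group on the amide carbonyl is not freely interchangeable: 4-methoxyphenyl in place of 1-benzothiophen-2-yl gives a 4.4-fold higher number from compound 1 to compound 3 (0.64 log units; beyond the scatter), so the kind of ring matters and not just its presence. Even so, among these compounds an aromatic ring at this place does better than methyl, with an at least 6.3-fold lower number from compound 2 to compound 3 (0.80 log units; beyond the scatter). Compound 2 stands at a limit and not at a number, so the true size of that second step is unknown: the limit of > 100000 nM in this assay, at which 1 of the 3 values shown sits.

Within the data shown here, with only two aromatic groups compared, it remains open whether the gap follows the sulfur, the five-membered ring or the methoxy group. Also open, as far as these compounds go, is where a plain phenyl, a 2-thienyl or a 4-aminophenyl group would fall on this scale.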